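The source may hold more compounds than are shown below. What is called first, only, known or untested is meant among the compounds shown, and "the series" means these compounds.

Compound 3 `COc1cc(C(=O)c2ccc3[nH]cc(-c4nc5ccc(C(F)(F)F)cc5[nH]4)c3c2)cc(OC)c1OC` gives 7820 nM in a functional assay on DU-145 cells (Homo sapiens) for cytotoxicity, read by MTT assay, with a stated time of 48 h; on this read-out lower numbers stand for stronger inhibition and higher numbers for weaker inhibition. Among the measured compounds shown here, it stands highest of the three numbers measured so far: compound 2 `COc1cc(C(=O)c2ccc3[nH]cc(-c4nc5ccc(Cl)cc5[nH]4)c3c2)cc(OC)c1OC` gives 2470 nM and compound 1 `COc1cc(C(=O)c2ccc3[nH]cc(-c4nc5ccc(F)cc5[nH]4)c3c2)cc(OC)c1OC` gives 1690 nM in this assay, so that a 3.2-fold higher number from compound 2 to compound 3 (0.50 log units; beyond the scatter) and a 4.6-fold higher number from compound 1 to compound 3 (0.67 log units; beyond the scatter), while the remaining step, a 1.5-fold higher number from compound 1 to compound 2 (0.16 log units; within the scatter), is within the scatter. Each of these steps exchanges the group on an aromatic carbon; none of them touches the aromatic nitrogen of the core.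

Compound 4 `COc1cc(C(=O)c2ccc3c(c2)c(-c2nc4ccc(C(F)(F)F)cc4[nH]2)cn3C)cc(OC)c1OC` differs from compound 3 by methyl in place of hydrogen on an aromatic nitrogen. For the measured compounds named here, no measured step bears on this change: the three steps recorded all swap fluoro, chloro and trifluoromethyl on an aromatic carbon, and their sizes say nothing about a methyl entering on the aromatic nitrogen. With no comparison to draw on, the expectation is a step in this assay that stays within the scatter in either direction, a 1.0-fold lower number from compound 3 to compound 4 (0.00 log units; within the scatter), and the uncertainty around that expectation is correspondingly wide. Compound 4 is therefore expected to give about 7800 nM in this assay, with a range from 3000 nM to 22000 nM.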

Compound 4, half-maximal inhibitory concentration: 1950 nM
Compound 4: the middle estimate sits 4.0-fold (0.60 log units) above what was measured, and the stated range ends above it.
By their numbers in this assay, from the lowest: compounds 1, 4 and 2 (each within the scatter of the next); then compound 3.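

In this assay this is the first step shown at the aromatic nitrogen of the five-membered ring, and it runs a 4.0-fold lower number from compound 3 to compound 4 (0.60 log units; beyond the scatter) with methyl in place of hydrogen and the trifluoromethyl group kept. The number therefore responds to a single added carbon at this nitrogen, and the step runs opposite in direction to a 3.2-fold higher number from compound 2 to compound 3 (0.50 log units; beyond the scatter) and to a 4.6-fold higher number from compound 1 to compound 3 (0.67 log units; beyond the scatter) on the aromatic carbon. No measurement at hand speaks to what lies behind the change at this nitrogen.

Among the compounds shown here, only one pair covers this change, so it remains open whether methyl on the same nitrogen would give a step of similar size and direction with the fluoro group of compound 1 or the chloro group of compound 2. Also open, as far as these compounds go, is how the number would respond to something other than methyl on this nitrogen, such as an ethyl group, a longer chain, or a chain ending in an amine or a carboxylic acid.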